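The source may hold more compounds than are shown below. What is called first, only, known or untested is meant among the compounds shown, and "the series" means these compounds.

The study centres on the shared core of compound 2 `O=[N+]([O-])c1ccc(-c2nc3cc(C(F)(F)F)ccc3n2C2CCCCC2)cc1`, which carries a cyclohexyl on its aromatic nitrogen and a nitro group on the six-membered aromatic ring of carbon only. Compound 1 `Cn1c(-c2ccc([N+](=O)[O-])cc2)nc2cc(C(F)(F)F)ccc21` carries a methyl in its place. In an ADME assay on BHK cells (Mesocricetus auratus) for cytotoxicity, read by MTT assay, with a stated time of 96 h (on this read-out higher numbers stand for lower toxicity in this test and lower numbers for higher toxicity in this test), compound 1 gives only a limit of > 100000 nM. In this assay compound 2 likewise gives only a limit of > 100000 nM. The step that the two limits leave unreadable from compound 1 to compound 2 therefore cannot be read. Compound 3 `COc1cc(-c2nc3cc(C(F)(F)F)ccc3[nH]2)cc(OC)c1OC`, with an unsubstituted aromatic nitrogen and methoxy groups on its six-membered aromatic ring of carbon only, gives 31000 nM in this assay. Compound 2 thus stands at the limit of > 100000 nM in this assay, at which 2 of the 3 values shown sit.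

Compound 4 `CCC(=O)Nc1ccc(-c2nc3cc(C(F)(F)F)ccc3n2C2CCCCC2)cc1` is the next compound to be measured. It differs from compound 2 in one place: propanoylamino in place of nitro on an aromatic carbon. For the measured compounds named here, no measured step touches this group, and the single measured step, the cyclohexyl exchange, is itself unreadable, so the measured steps give no size for the change. Compound 4 is therefore expected to sit close to the limit, with the expected step of an at least 1.2-fold lower number from compound 2 to compound 4 (0.09 log units; that floor lies within the scatter) not readable beyond the scatter. The estimate for compound 4 is 80000 nM, with a range from 20000 nM to 300000 nM, and a sizeable chance that this assay again reports only a limit.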

Compound 4, half-maximal cytotoxic concentration: 15000 nM
Beside the measured number, compound 4's estimate is 5.3-fold (0.73 log units) above it, and the stated range ends above it.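

In this assay, for the compounds shown here, propanoylamino in place of nitro on the aromatic carbon para to a large group gives an at least 6.6-fold lower number from compound 2 to compound 4 (0.82 log units; beyond the scatter), the first step that can be read, and it runs towards higher toxicity in this test. Going by these compounds alone, the true size of this step may be greater, and it is stated only as a floor, since the value of compound 2 is a limit and not a number: the limit of > 100000 nM in this assay, at which 2 of the 4 values shown sit. The exchange on the aromatic nitrogen could not be read, so this position on the six-membered aromatic ring of carbon only is the first place where a single change is seen to move the read-out, with 5 heavy atoms and 1 hydrogen-bond donor entering for 3 heavy atoms and 0 hydrogen-bond donors.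

The compounds shown do not tell whether the amide as such, the length of its chain or simply the loss of nitro accounts for the step, which a free amine or an acetylamino group at this position would help to separate. They also leave open whether the same exchange would give a similar step with methyl in place of cyclohexyl on the aromatic nitrogen.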